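The source may report more compounds than this note shows. Statements on the series, on what has been measured and on what is new or still open speak of the compounds shown alone.

Compound 3 `COc1cccc(CNCCCNc2ccnc3cc(-c4ccc(F)cc4)ccc23)c1O` shares its core with compound 1 `FC(F)(F)c1ccc(-c2ccc3c(NCCCNCc4ccco4)ccnc3c2)cc1` and compound 2 `Fc1ccc(-c2ccc3c(NCCCNCc4ccco4)ccnc3c2)cc1`. In a physicochemical assay for solubility, with a stated time of 18 h, at pH 7.4 (a lower number here means a less soluble compound, a higher number a more soluble compound), compound 1 gives 32000 nM, compound 2 gives 32000 nM, and compound 3 gives 32000 nM. Compound 3 thus stands level with both of the others: the step of no change at the digits printed from compound 1 to compound 2 (within the scatter) and the step of no change at the digits printed from compound 2 to compound 3 (within the scatter) each lie within the scatter. Compound 4 `COc1cccc(Oc2ccc3c(NCCCNCc4cccc(OC)c4O)ccnc3c2)c1` differs from compound 3 in one place: 3-methoxyphenoxy in place of 4-fluorophenyl on an aromatic carbon. Among the measured compounds shown here, no measured step touches the same place; the two steps that are known, one exchanging a group on an aromatic carbon and one exchanging the group on a saturated chain carbon bound to an amine nitrogen, both left this assay unchanged. Compound 4 is therefore expected to show no step beyond the scatter, no change at the digits printed from compound 3 to compound 4 (within the scatter). Compound 4 is estimated at 32000 nM in this assay. The lower end of that estimate for compound 4 is 14000 nM. The upper end of the estimate for compound 4 is 64000 nM.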

Compound 4, solubility: 14500 nM
The estimate for compound 4 lay 2.2-fold (0.34 log units) above the measured number, and the stated range covers the measured number.
By their numbers in this assay, from the lowest: compound 4; then compounds 1, 2 and 3 (each within the scatter of the next).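

At this aromatic carbon of the shared core, in this assay, 3-methoxyphenoxy in place of 4-fluorophenyl gives a 2.2-fold lower number from compound 3 to compound 4 (0.34 log units; beyond the scatter), a modest step but one beyond the scatter. The two earlier exchanges, at other places, had left the number unchanged at the digits printed, so this position is the only one of the three where a change moved the read-out. The entering group has 9 heavy atoms against 7 and 2 hydrogen-bond acceptors against 0, but no measurement here ties the step to any property of either group. This single step changes the ring's substituent and its link to the core together, so it cannot say which of them goes with the lower number. As far as these compounds go, how a plain phenoxy, a directly attached 3-methoxyphenyl or an amine at this carbon would read remains open.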